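A few compounds are considered here, and "the series" means these few. Any claim that something is new, unique, unknown or untested is made for them only; others in the source may bear on it.

Compound 2 `COc1cc(C2=NO[C@]3(C2)C(=O)O[C@@H]2[C@H]3CC[C@H](C)[C@]3(O)C=CC(=O)[C@@]23C)ccc1O` gives 88000 nM in a functional assay on SW-620 cells (Homo sapiens) for cytotoxicity, read by sulforhodamine B assay, with a stated time of 48 h (a lower number here means a stronger inhibitor, a higher number a weaker inhibitor), the highest of the two numbers recorded; its nearest neighbour, compound 1 `C[C@H]1CC[C@@H]2[C@@H](OC(=O)[C@]23CC(c2ccc(N(C)C)cc2)=NO3)[C@]2(C)C(=O)C=C[C@@]12O`, gives 5100 nM. Compound 3 `C[C@H]1CC[C@@H]2[C@@H](OC(=O)[C@]23CC(c2ccc(C#N)cc2)=NO3)[C@]2(C)C(=O)C=C[C@@]12O` differs from compound 2 in one place: 4-cyanophenyl in place of 4-hydroxy-3-methoxyphenyl on a carbon with a double bond to nitrogen. Among the compounds with values here, the only measured step bearing on this site is a 17-fold higher number from compound 1 to compound 2 (1.24 log units; beyond the scatter), which shows that exchanging the aryl group here can shift the number a great deal. Since compound 2 stands highest and its 4-hydroxy-3-methoxyphenyl leaves, a lower number is expected for compound 3, about 9000 nM (range 2000 nM to 45000 nM), a step of a 9.8-fold lower number from compound 2 to compound 3 (0.99 log units; beyond the scatter).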

Compound 3, half-maximal inhibitory concentration: 53000 nM
The estimate for compound 3 lay 5.9-fold (0.77 log units) below the measured number; measured number above the stated range.
By their numbers in this assay, from the lowest: compound 1; then compounds 3 and 2 (each within the scatter of the next).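

Placing 4-cyanophenyl where 4-hydroxy-3-methoxyphenyl stood gives a 1.7-fold lower number from compound 2 to compound 3 (0.22 log units; within the scatter), so this assay does not separate these two aryl groups. Cyano in place of dimethylamino on an aromatic carbon gives a 10-fold higher number from compound 1 to compound 3 (1.02 log units; beyond the scatter), so among these three compounds only compound 1, with its 4-(dimethylamino)phenyl, stands apart. Nothing supplied here accounts for this difference. From the compounds shown here alone, it remains open whether the difference is specific to dimethylamino or extends to other amines, such as a primary amine or a morpholine. A carboxylic acid on the aryl ring also remains untested among the compounds shown.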